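A few compounds are considered here, and "the series" means these few. Any claim that something is new, unique, unknown or untested is made for them only; others in the source may bear on it.

Working notes on the series: in a functional assay on MKN-45 cells (Homo sapiens) for antiproliferative activity, read by MTT assay, with a stated time of 72 h (a lower number here means a stronger inhibitor, a higher number a weaker inhibitor), compound 1 (`COc1cc2c(Oc3ccc(Nc4nccc5[nH]cc(-c6ccc(F)cc6)c(=O)c45)cc3F)ccnc2cc1OCCO`) gives 1600 nM and compound 2 (`O=c1c(-c2ccc(F)cc2)c[nH]c2ccnc(Nc3ccc(Oc4ccnc5cc(OCCO)ccc45)c(F)c3)c12`) gives 4700 nM, the higher of the two numbers. Compound 3 (`CC(C)(O)COc1ccc2c(Oc3ccc(Nc4nccc5[nH]cc(-c6ccc(F)cc6)c(=O)c45)cc3F)ccnc2c1`) carries 1-hydroxy-1-methylethyl in place of hydroxymethyl on a saturated chain carbon bound to an oxygen on an aromatic ring, which also reads as 2-hydroxy-2-methylpropoxy in place of 2-hydroxyethoxy. Going by the values given here, the only measured step, a 2.9-fold higher number from compound 1 to compound 2 (0.47 log units; beyond the scatter), is modest and lies at another place, hydrogen in place of methoxy on an aromatic carbon. Among the compounds with values here, no measured step covers the new change. In this assay, no shift beyond the scatter is expected, and no direction is favoured. The expected step is a 1.2-fold lower number from compound 2 to compound 3 (0.07 log units; within the scatter). For compound 3 the estimated value is 4000 nM, with an expected range of 1500 nM to 11000 nM.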

Compound 3, half-maximal inhibitory concentration: 2700 nM
Beside the measured number, compound 3's estimate is 1.5-fold (0.17 log units) above it; the range from low to high includes it.
By their numbers in this assay, from the lowest: compounds 1, 3 and 2 (each within the scatter of the next, the first and the last beyond it).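

In this assay, this first measured change on the chain gives a 1.7-fold lower number from compound 2 to compound 3 (0.24 log units; within the scatter), so 2-hydroxy-2-methylpropoxy and 2-hydroxyethoxy cannot be told apart here. At this place, the larger 1-hydroxy-1-methylethyl group is therefore tolerated, with the hydroxyl retained in both compounds. Nothing available bears on the reason for this result. As far as these compounds go, it remains open how an amine, a carboxylic acid or a longer chain would read in place of 2-hydroxyethoxy. Also open, from the compounds shown here alone, is whether the same exchange would read alike with the methoxy group of compound 1 present.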